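The compounds below may be only part of what the source reports. "The series", "measured", "known", "first", "only" and "open" are said of these compounds alone.

Values so far in a functional assay on SK-BR-3 cells (Homo sapiens) for cytotoxicity, read by MTT assay, with a stated time of 72 h (a lower number here means a stronger inhibitor, a higher number a weaker inhibitor), for the half-maximal inhibitory concentration:
- compound 1 `N[C@H]1CC[C@H](Nc2c(C(=O)NCc3ccc(F)cc3)nc(N3CCCCS3(=O)=O)c3cccnc23)CC1` gives 8500 nM
- compound 2 `Nc1cccc(Nc2c(C(=O)NCc3ccc(F)cc3)nc(Br)c3cccnc23)c1` gives > 10000 nM
- compound 3 `N[C@H]1CC[C@H](Nc2c(C(=O)NCc3ccco3)nc(Br)c3cccnc23)CC1` gives 10000 nM

The entry for compound 2 at > 10000 nM is a limit of the assay and not a number.

Compound 1 at 8500 nM and compound 3 at 10000 nM lie within the scatter of each other. Compound 3 therefore has a single numeric neighbour and stands level with it.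

The compound awaiting measurement is compound 4 `N[C@H]1CC[C@H](Nc2c(C(=O)NCc3ccc(Cl)cc3)nc(Br)c3cccnc23)CC1` and it differs from compound 3 as follows: 4-chlorophenyl in place of furan-2-yl on a saturated chain carbon bound to an amide-type nitrogen in all. Cut one bond further out, the same change reads (furan-2-yl)methyl to 4-chlorobenzyl.

Among the compounds with values here, no measured pair isolates this change. With compound 3 at 10000 nM as the only anchor, no step beyond the scatter is expected in this assay for this replacement, with a slight lean toward a lower number. The estimate amounts to an expected move a 1.5-fold lower number from compound 3 to compound 4 (0.19 log units; within the scatter) and no more than that.

For compound 4 the estimated value is 6500 nM with an expected range from 2000 nM to 15000 nM in this read-out.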

Compound 4, half-maximal inhibitory concentration: 2000 nM
Compound 4: middle estimate off by 3.3-fold (0.51 log units), on the high side; the measured number falls inside the stated range.
By their numbers in this assay, from the lowest: compound 4; then compounds 1 and 3 (each within the scatter of the next).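

In this assay, within the data shown here, this place, a saturated chain carbon bound to an amide-type nitrogen, turns out to respond to a change of group: going from (furan-2-yl)methyl to 4-chlorobenzyl gives a 5.0-fold lower number from compound 3 to compound 4 (0.70 log units; beyond the scatter) and is the only step that can be read, a modest one. The earlier compounds could not show this, as no two of them differ in one place, and the other comparisons among the compounds shown cannot be read either. Nothing measured here gives a cause for the step.

On these data alone, the change swaps a five-membered aromatic ring with one hetero atom for a six-membered carbon ring and brings in chlorine at the same time, so the share of each stays open; plain benzyl at this place would separate the two, and a longer chain such as 2-phenylethyl would show whether the distance from the amide-type nitrogen matters. As far as these compounds go, whether the same replacement gives a step of similar size on the cores of compound 1 and compound 2 also stays open.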